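Phenyl to Dimethylthiazolyl: What Compound 3 May Dissolve

The compounds below may be only part of what the source reports. "The series", "measured", "known", "first", "only" and "open" are said of these compounds alone.

Of the compounds shown here, two have been measured in a physicochemical assay for solubility, in phosphate buffer, measured as kinetic solubility, with a stated time of 1 h, at pH 7.4; a lower number here means a less soluble compound, a higher number a more soluble compound. Compound 1 `CSc1ccc2nc(C)cc(OCC(=O)Nc3cc(C)cc(C)c3)c2c1` gives 3000 nM in this assay. Compound 2 `COc1ccc2nc(C)cc(OCC(=O)Nc3ccccc3)c2c1` gives 63000 nM, the higher of the two numbers, and the gap between compound 2 and compound 1 lies well beyond the scatter of repeated measurements. Compound 3 `COc1ccc2nc(C)cc(OCC(=O)Nc3nc(C)c(C)s3)c2c1` is the next member and has not yet been measured in this assay. Its structure departs from compound 2 in one place: 4,5-dimethyl-1,3-thiazol-2-yl in place of phenyl on an amide-type nitrogen. Going by the values given here, no measured pair in this set carries that particular change, so its effect can only be anticipated. With compound 2 as the reference, the expected step of a 2.1-fold lower number from compound 2 to compound 3 (0.32 log units; beyond the scatter) is a modest decrease, one that may not clearly exceed the scatter. In this assay compound 3 is therefore estimated at 30000 nM, with a likely range from 8000 nM to 100000 nM.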

Compound 3, solubility: 31500 nM
Beside the measured number, compound 3's estimate is 1.1-fold (0.02 log units) below it; the measured number falls inside the stated range.
By their numbers in this assay, from the lowest: compound 1; then compounds 3 and 2 (each within the scatter of the next).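

In this assay, going by these compounds alone, the step of a 2.0-fold lower number from compound 2 to compound 3 (0.30 log units; within the scatter) is the first reading of a single change, and it concerns the group on the amide-type nitrogen. At this place, 4,5-dimethyl-1,3-thiazol-2-yl, a five-membered aromatic ring with 2 hetero atoms and 2 hydrogen-bond acceptors, takes the place of phenyl, a six-membered aromatic ring of carbon only, and the two numbers stay within the scatter of each other. No measurement here offers a reason for this result.

The compounds shown leave open what the ring itself and its two methyl groups each contribute in this assay, which a 1,3-thiazol-2-yl without the methyl groups would separate. Also open, going by these compounds, is how this place responds to a different kind of group, such as a pyridine ring or a carboxylic acid on the phenyl.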